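Sulfonamide aryl swap on a chromone-ether anilide scaffold

A few compounds are considered here, and "the series" means these few. Any claim that something is new, unique, unknown or untested is made for them only; others in the source may bear on it.

Measured compounds:
compound 1 `CCCC(=O)Nc1cccc(NC(=O)COc2ccc3c(=O)ccoc3c2)c1` — 1430 nM
compound 2 `CC(C)(C)c1ccc(S(=O)(=O)Nc2cccc(NC(=O)COc3ccc4c(=O)ccoc4c3)c2)cc1` — > 10000 nM

Of the compounds shown here, two have been tested in an assay on isolated protein for inhibition of Rho-associated protein kinase 1 (Homo sapiens), read by scintillation counting, radiometric assay and 33P incorporation, with a stated time of 40 min, in the presence of a further agent that is not named here; a lower number here means a stronger inhibitor, a higher number a weaker inhibitor. Compound 1 gives 1430 nM. Compound 2 carries a sulfonamide in place of the butanamide of compound 1. Compound 2 reaches only a limit of the assay, > 10000 nM; this is the limit at which one of the two values sits (the limit of > 10000 nM in this assay, at which 1 of the 2 values shown sits). Nothing beyond that limit is known for compound 2, so the step from compound 1 to compound 2 cannot be sized.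

Compound 3 `O=C(COc1ccc2c(=O)ccoc2c1)Nc1cccc(NS(=O)(=O)c2ccc(OC(F)(F)F)cc2)c1` is not yet measured. It differs from compound 2 in one place: trifluoromethoxy in place of tert-butyl on an aromatic carbon. Among the compounds with values here, no measured pair shows this change, so there is no step to lean on. Given that compound 2 reports only a limit, compound 3 is expected to stay weak as well, with the step that the limit leaves unreadable from compound 2 to compound 3 expected to amount to no more than the usual scatter in this assay. The estimate for compound 3 is 12000 nM, with a range from 3000 nM to 40000 nM, and a substantial chance that the assay again reports only a limit.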

Compound 3, half-maximal inhibitory concentration: 6440 nM
For compound 3 the middle estimate is 1.9-fold (0.27 log units) above the measured one; the range from low to high includes it.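

In this assay, within the data shown here, compound 3 gives 6440 nM, which is the first reading with a sulfonamide link that is a number rather than a limit, with trifluoromethoxy on an aromatic carbon para to a large group. Trifluoromethoxy in place of tert-butyl at this position gives an at least 1.5-fold lower number from compound 2 to compound 3 (0.19 log units; that floor lies within the scatter), so the change is not shown to exceed the scatter, although its true size could be larger. Compound 2 reports only a limit of the assay, > 10000 nM, and so the step has a floor but no measured size: the limit of > 10000 nM in this assay, at which 1 of the 3 values shown sits.

Going by these compounds, how far the true step lies beyond that floor remains open, as does the way this position would respond to a different para group, such as an amine, a carboxylic acid or a longer chain in place of trifluoromethoxy. Also open is what the sulfonamide link itself contributes to the reading, as the compounds shown offer no readable step that isolates it from the aryl group it carries.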